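The compounds below may be only part of what the source reports. "The series", "measured", "known", "first", "only" and "open" are said of these compounds alone.

Among the compounds with values here, in an ADME assay for permeability (a lower number here means that the compound crosses the layer more slowly, a higher number that the compound crosses the layer faster), compound 2 (`CNC(=O)c1cc(C(=O)N[C@H]2CC[C@H](O)CC2)n([C@@H](C)c2ccccc2)n1`) gives 80 nm/s as the lowest of the three numbers measured so far. Compound 1 (`CNC(=O)c1cc(C(=O)NC2CCOCC2)n([C@@H](C)c2ccccc2)n1`) gives 270 nm/s and compound 3 (`CNC(=O)c1cc(C(=O)N[C@H]2CC[C@H](OC)CC2)n([C@@H](C)c2ccccc2)n1`) gives 360 nm/s and these two lie within the scatter of each other. Compound 4 (`CNC(=O)c1cc(C(=O)N[C@H]2CC[C@H](O)CC2)n([C@@H](C)c2ccccc2Cl)n1`) keeps the 4-hydroxycyclohexyl group of compound 2 and turns phenyl into 2-chlorophenyl (chloro in place of hydrogen on an aromatic carbon). Within the data shown here, no measured step touches that phenyl, so none is a direct guide. Among the measured compounds shown here, the only evidence comes from changes at the other end of the molecule, on the amide-type nitrogen. One such change gave a 3.4-fold lower number from compound 1 to compound 2 (0.53 log units; beyond the scatter) and another gave a 4.5-fold higher number from compound 2 to compound 3 (0.65 log units; beyond the scatter) while a third gave a 1.3-fold higher number from compound 1 to compound 3 (0.12 log units; within the scatter) in this small set. These steps show only how far this assay has moved so far. A slight rise is the working expectation, with a fall still possible, and the expected change is a 1.4-fold higher number from compound 2 to compound 4 (0.14 log units; within the scatter) within the scatter. For compound 4 the estimated value is 110 nm/s with 45 nm/s to 240 nm/s as the expected range.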

Compound 4, apparent permeability: 100 nm/s
Compound 4: the middle estimate sits 1.1-fold (0.04 log units) above what was measured; the range from low to high includes it.
By their numbers in this assay, from the lowest: compounds 2 and 4 (each within the scatter of the next); then compounds 1 and 3 (each within the scatter of the next).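

Within the data shown here, this is the first measured change at the phenyl end of the molecule: chloro in place of hydrogen on an aromatic carbon, ortho to a large group, gives a 1.3-fold higher number from compound 2 to compound 4 (0.10 log units; within the scatter) in this assay. So with the 4-hydroxycyclohexyl group on the amide-type nitrogen, this change leaves no shift that can be told from the scatter, whereas capping the hydroxyl at the other end with methyl gave a 4.5-fold higher number from compound 2 to compound 3 (0.65 log units; beyond the scatter). No measurement shown gives a reason for this outcome.

A single chloro on a single parent leaves open how a different group at this position, such as fluoro, methoxy or an amine, would read. Also open, going by these compounds, is whether chloro would read the same alongside the oxan-4-yl or 4-methoxycyclohexyl group.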